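Sulfide to sulfone at the acyl side chain

The source may hold more compounds than are shown below. What is called first, only, known or untested is meant among the compounds shown, and "the series" means these compounds.

Measured compounds:
compound 1 `C[C@@H]1CN(Cc2ccc(-c3ccccc3CN(C)C(=O)COc3ccccc3)cc2)C[C@H](C)N1` gives 79.4 nM in a functional assay on HEK293 cells for agonist activity at Motilin receptor (Homo sapiens), read by FLIPR; a higher number here means that more compound is needed for the effect, a lower number that less compound is needed
compound 2 `C[C@@H]1CN(Cc2ccc(-c3ccccc3CN(C)C(=O)COc3ccc(F)cc3)cc2)C[C@H](C)N1` gives 31.6 nM in this assay
compound 3 `C[C@@H]1CN(Cc2ccc(-c3ccccc3CN(C)C(=O)CSc3ccccc3)cc2)C[C@H](C)N1` gives 3.16 nM in this assay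

Among these three, compound 3 stands lowest, meaning the least compound is needed for the effect; the steps of a 25-fold lower number from compound 1 to compound 3 (1.40 log units; beyond the scatter) and a 10-fold lower number from compound 2 to compound 3 (1.00 log units; beyond the scatter) are both beyond the scatter, so its lead is real. Compound 4 `C[C@@H]1CN(Cc2ccc(-c3ccccc3CN(C)C(=O)CS(=O)(=O)c3ccccc3)cc2)C[C@H](C)N1` keeps the shared core and changes only the group on the acyl side chain: phenylsulfonyl in place of phenylsulfanyl on a saturated chain carbon bound to a carbonyl carbon.

For the measured compounds named here, no measured step covers this exact change. The steps that come closest replace the oxygen-linked phenyl groups of compound 1 and compound 2 by the sulfur-linked group of compound 3, and both move downward strongly, as a 25-fold lower number from compound 1 to compound 3 (1.40 log units; beyond the scatter) shows. Whether adding oxygens onto that sulfur keeps the gain is not answered by the data. The expectation is a modest loss, a 9.5-fold higher number from compound 3 to compound 4 (0.98 log units; beyond the scatter), with wide uncertainty. Compound 4 is therefore estimated at 30 nM, within a range from 5 nM to 200 nM.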

Compound 4, half-maximal effective concentration: 10 nM
For compound 4 the middle estimate is 3.0-fold (0.48 log units) above the measured one; low and high end bracket the measured number.
By their numbers in this assay, from the lowest: compound 3; then compound 4; then compound 2; then compound 1.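

Adding two oxygens to the sulfur on the acyl side chain has a price in this assay, a 3.2-fold higher number from compound 3 to compound 4 (0.50 log units; beyond the scatter). Even so, the phenylsulfonyl group keeps an edge over both oxygen-linked groups, with a 3.2-fold lower number from compound 2 to compound 4 (0.50 log units; beyond the scatter) and a 7.9-fold lower number from compound 1 to compound 4 (0.90 log units; beyond the scatter), so part of the gain seen with sulfur survives the change. Nothing among the data shown explains why the order of these groups falls as it does.

The compounds shown leave open how a sulfoxide, with a single oxygen on that sulfur, or an amine nitrogen in place of that sulfur would compare. Going by these compounds, it is also open whether a fluoro on the phenyl of phenylsulfanyl or phenylsulfonyl would repeat the shift seen among the oxygen-linked groups, a 2.5-fold lower number from compound 1 to compound 2 (0.40 log units; beyond the scatter).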